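Notes on a cytotoxicity series: compounds 1 to 3

The source may hold more compounds than are shown below. What is called first, only, known or untested is meant among the compounds shown, and "the series" means these compounds.

Measured so far in a functional assay on HeLa cells (Homo sapiens) for cytotoxicity, read by MTT assay, with a stated time of 2 days, tested at 100 uM; on this read-out lower numbers stand for a stronger effect and higher numbers for a weaker effect at the one concentration tested:
- compound 1 `COc1ccc(-c2cc(C(C)=O)c3[nH]c(-c4ccc(OC)cc4)cc3c2)cc1`: 20.2%
- compound 2 `CC(=O)c1cc(/C=C/c2ccc(F)cc2)cc2cc(-c3ccccc3)[nH]c12`: 23.9%

On these two numbers compound 2 stands highest, but its nearest neighbour, compound 1, lies within the scatter of it, so the two values cannot be told apart. Among the compounds with values here, no step between measured compounds that differ in one place is available; compound 1 and compound 2 differ in more than one place, so nothing beyond their two values can be read from them.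

Compound 3 `COc1ccc(-c2cc3cc(/C=C/c4ccc(F)cc4)cc(C(C)=O)c3[nH]2)cc1` is the next compound and is to be measured in this assay. It differs from compound 2 in one place: methoxy in place of hydrogen on an aromatic carbon. Compound 1 already carries the 4-methoxyphenyl and gives a number close to that of compound 2, so no step beyond the scatter is expected from compound 2 to compound 3. The expected step is a number 1.9 percentage points lower from compound 2 to compound 3 (within the scatter). For compound 3 the estimate is 22% with a range from 8% to 40%.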

Compound 3, a percentage reported as activity, at one concentration (the size of the read-out at that concentration, not a potency): 18.9%
The estimate for compound 3 lay 3.1 percentage points above the measured number; low and high end bracket the measured number.
By their numbers in this assay, from the lowest: compounds 3, 1 and 2 (each within the scatter of the next).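

Within the data shown here, this is the first one-place reading at this position: in this assay the change from phenyl to 4-methoxyphenyl gives a number 5 percentage points lower from compound 2 to compound 3 (within the scatter), so methoxy in place of hydrogen on this aromatic carbon cannot be told apart from hydrogen here. The other site now has a reading too: 2-(4-fluorophenyl)ethenyl in place of 4-methoxyphenyl gives a number 1.3 percentage points lower from compound 1 to compound 3 (within the scatter), so these two large groups cannot be told apart on this read-out either. No supporting measurement bears on the reason for either step.

Going by these compounds, whether an amine or a carboxylic acid in place of the methoxy would move the number beyond the scatter remains open. On these data alone, with every number taken at one concentration, each shows only the size of the effect at that concentration, and whether compounds 1, 2 and 3 would give a stronger or weaker effect at any other concentration also remains open.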